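The source may hold more compounds than are shown below. What is called first, only, known or untested is meant among the compounds shown, and "the series" means these compounds.

Measured so far in a functional assay on A549 cells (Homo sapiens) for antiproliferative activity, read by MTT assay, with a stated time of 48 h; a higher number here means a weaker inhibitor, a lower number a stronger inhibitor:

Compound 1, `COc1ccc(-n2nncc2CN2C(=O)C3(C(C#N)=C(N)Oc4c3c3nc5ccccc5nc3c3ccccc43)c3ccccc32)cc1`, gives > 50000 nM, a limit of this assay rather than a number.
Compound 2, `COc1ccccc1-n1nncc1CN1C(=O)C2(C(C#N)=C(N)Oc3c2c2nc4ccccc4nc2c2ccccc32)c2ccccc21`, gives > 50000 nM, likewise a limit.
Compound 3, `COc1ccc(-n2nncc2CN2C(=O)C3(C(C#N)=C(N)Oc4c(N)cc5nc6ccccc6nc5c43)c3ccccc32)cc1`, gives > 50000 nM, again a limit.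

Compounds 1 and 2 share one core and differ in one place: 2-methoxyphenyl in place of 4-methoxyphenyl on an aromatic nitrogen. For the measured compounds named here, because both values sit at the limit, the step that the two limits leave unreadable from compound 1 to compound 2 cannot be read, so the data say only that neither compound inhibits cell growth within the range this assay can resolve. Compound 3 is built on a core that carries an extra amino group; how its core differs from that of compound 1 is not broken down here. What is clear is the limit of > 50000 nM in this assay, at which 3 of the 3 values shown sit, so none of the three measured compounds has shown any measurable activity.

Compound 4, `COc1ccccc1-n1nncc1CN1C(=O)C2(C(C#N)=C(N)Oc3c(N)cc4nc5ccccc5nc4c32)c2ccccc21`, has not been measured. It relates to compound 3 exactly as compound 2 relates to compound 1, by the same change: 2-methoxyphenyl in place of 4-methoxyphenyl on an aromatic nitrogen. The expectation for compound 4 therefore rests on one observation only: that the same change, made on the other core, left compound 2 at the limit just as compound 1 was, and that compound 3 itself is at the limit. On that basis compound 4 is expected to sit at the limit as well, with the step that the limit leaves unreadable from compound 3 to compound 4 estimated to be unreadable. The estimated value for compound 4 is 60000 nM, within 25000 nM to 150000 nM, though a number rather than a limit would be a surprise.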

Compound 4, half-maximal inhibitory concentration: 37500 nM
Compound 4: the middle estimate sits 1.6-fold (0.20 log units) above what was measured; the range from low to high includes it.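

On the core that carries the extra amino group, putting 2-methoxyphenyl in place of 4-methoxyphenyl on the aromatic nitrogen gives an at least 1.3-fold lower number from compound 3 to compound 4 (0.12 log units; that floor lies within the scatter). Compound 4 is the only compound shown with a number rather than a limit, but with that floor inside the scatter, the data do not establish that the change made the compound any stronger. The matching step on the core of compound 1 cannot be read, and this leaves no two sizes to set side by side, so the data cannot say whether the change carries from one core to the other, and the series as a whole remains thinly resolved: the limit of > 50000 nM in this assay, at which 3 of the 4 values shown sit.

The compounds shown leave open whether any other group on this phenyl ring, such as a 3-methoxy group, a dimethylamino group or a carboxylic acid, would bring a value clearly inside the range of this assay. They also leave open what would follow if the extra amino group on the core were replaced by a hydroxyl group or an acetamide.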